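Adding a Second Methoxy to a Chalcone Styryl Ring

A few compounds are considered here, and "the series" means these few. Any claim that something is new, unique, unknown or untested is made for them only; others in the source may bear on it.

Of the compounds shown here, two have been measured so far in a functional assay on SW480 cells (Homo sapiens) for antiproliferative activity, read by sulforhodamine B assay, with a stated time of 48 h; on this read-out higher numbers stand for weaker inhibition and lower numbers for stronger inhibition. Compound 1 `COc1ccc(-c2ccccc2C(=O)/C=C/c2ccc(F)cc2)cc1OC` gives 6800 nM, while compound 2 `COc1ccc(/C=C/C(=O)c2ccccc2-c2ccc(OC)c(OC)c2)cc1` gives 890 nM. Among the measured compounds shown here, of these two numbers compound 2 has the lower one, and the single measured step, a 7.6-fold lower number from compound 1 to compound 2 (0.88 log units; beyond the scatter), is the only comparison available.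

Compound 3 `COc1ccc(/C=C/C(=O)c2ccccc2-c2ccc(OC)c(OC)c2)cc1OC` differs from compound 2 in one place: methoxy in place of hydrogen on an aromatic carbon. Cut one bond further out, the change reads 4-methoxyphenyl to 3,4-dimethoxyphenyl, on the same ring that carried the change from compound 1 to compound 2. That earlier step involved a different group swap, so it shows the ring is sensitive to what sits on it but does not directly tell what one more methoxy will do. For the measured compounds named here, no measured step mirrors the present change, so the expectation rests on the absence of a clear signal.

The step from compound 2 to compound 3 is therefore expected to be small, a 1.3-fold lower number from compound 2 to compound 3 (0.10 log units; within the scatter), within or near the scatter. Compound 3 is estimated at 700 nM, with a range of 250 nM to 2500 nM.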

Compound 3, half-maximal inhibitory concentration: 7600 nM
Beside the measured number, compound 3's estimate is 11-fold (1.04 log units) below it; measured number above the stated range.
By their numbers in this assay, from the lowest: compound 2; then compounds 1 and 3 (each within the scatter of the next).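

In this assay the extra methoxy is far from a neutral change: going from 4-methoxyphenyl to 3,4-dimethoxyphenyl gives an 8.5-fold higher number from compound 2 to compound 3 (0.93 log units; beyond the scatter) and shows that this ring position responds strongly to a single added group, here placed ortho to a methoxy group. The comparison with the fluorine-bearing compound gives a 1.1-fold higher number from compound 1 to compound 3 (0.05 log units; within the scatter) and places the two at the same level, so among the three groups shown only 4-methoxyphenyl stands out with a lower number, and adding more of a group that went with a lower number did not lower it further. Nothing measured here explains why the extra methoxy has this effect.

On these data alone, what remains open is whether this loss belongs to methoxy in particular or would follow any group placed on that same ring carbon. A hydroxy group or a chlorine atom there, or an ethoxy group in place of the added methoxy, would help separate these two readings, while the shared core stays unchanged.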